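From methyl to acetamidomethyl on compound 2

The source may report more compounds than this note shows. Statements on the series, on what has been measured and on what is new or still open speak of the compounds shown alone.

In a functional assay on MT4 cells (Homo sapiens) for cytotoxicity, read by CellTiter-Glo, with a stated time of 5 days (on this read-out lower numbers stand for an effect already at smaller amounts and higher numbers for an effect only at larger amounts of compound), compound 2 `Cc1ccc(-c2c(C)noc2C)cc1S(=O)(=O)NC1CCCC1` gives 1590 nM. Compound 1 `Cc1noc(C)c1-c1cc(S(=O)(=O)NC2CCCC2O)c2cc(N)c(=O)[nH]c2c1` gives 970 nM, within the scatter of the value for compound 2, so these two share the upper end of the three numbers. Compound 3 `Cc1ccc2ncccc2c1-c1cc(-c2c(C)noc2C)cc2nc(C3CC3)[nH]c12` gives 18 nM, lower than both and beyond the scatter.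

Compound 4 `CC(=O)NCc1onc(C)c1-c1ccc(C)c(S(=O)(=O)NC2CCCC2)c1` differs from compound 2 in one place: acetamido in place of hydrogen on a saturated chain carbon bound to an aromatic carbon. This is acetamido in place of hydrogen on a saturated chain carbon bound to an aromatic carbon, which turns a methyl into an acetamidomethyl. Within the data shown here, no measured pair shows this change, so the value of compound 2 at 1590 nM is the only anchor. The working expectation in this assay is a small move toward a higher number, which may not clear the scatter: a 1.8-fold higher number from compound 2 to compound 4 (0.25 log units; within the scatter). For compound 4 the estimated value is 2800 nM, with an expected range from 900 nM to 9000 nM.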

Compound 4, half-maximal effective concentration: 4920 nM
Estimate against measurement, compound 4: 1.8-fold (0.24 log units) below; measured number inside the range.
By their numbers in this assay, from the lowest: compound 3; then compounds 1 and 2 (each within the scatter of the next); then compound 4.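

In this assay, acetamido in place of hydrogen on a saturated chain carbon bound to an aromatic carbon gives a 3.1-fold higher number from compound 2 to compound 4 (0.49 log units; beyond the scatter). Among these compounds, this is the first step that can be read as a single change, since no earlier pair differed in one place, and it shows that the number at this position responds to the methyl becoming an acetamidomethyl. The step rests on one pair, and nothing measured here bears on the reason for it.

The compounds shown leave open whether the step belongs to the acetamido group itself or would also follow from other groups on this carbon, such as an amine in aminomethyl, a hydroxymethyl or a longer chain. Also open, from the compounds shown here alone, is whether the same change on the core of compound 1 or compound 3 would move the number in the same direction.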